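Swapping an Aryl Ether Tail in a Receptor Agonist Series

A few compounds are considered here, and "the series" means these few. Any claim that something is new, unique, unknown or untested is made for them only; others in the source may bear on it.

Of the compounds shown here, two sharing one core have been measured in a functional assay on CHO cells for agonist activity at metabotropic glutamate receptor 2 (Homo sapiens), read by GTPgammaS binding; a higher number here means a larger maximal response, a lower number a smaller maximal response. Compound 1 `CCCn1ccc2cc(-c3ccc(N(C)C)nc3)cc(Cl)c2c1=O` gives 85%. Compound 2 `CCCn1ccc2cc(-c3ccc(Oc4ccccc4)nc3)cc(Cl)c2c1=O` gives 92%. The step of a number 7 percentage points higher from compound 1 to compound 2 (within the scatter) comes with phenoxy in place of dimethylamino on an aromatic carbon. Compound 2 holds the higher of the two numbers, yet its gap to compound 1 is within the scatter, so the two cannot be told apart on these data.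

Compound 3 `CCCn1ccc2cc(-c3ccc(OCc4cccnc4)nc3)cc(Cl)c2c1=O` is not yet measured. It differs from compound 2 in one place: (pyridin-3-yl)methyl in place of phenyl on an oxygen on an aromatic ring. Among the compounds with values here, no measured step matches this kind of change. Within the data shown here, the only guide is the step of a number 7 percentage points higher from compound 1 to compound 2 (within the scatter), which left the maximal response essentially unchanged when a different group was placed at this part of the molecule. A step of similar size, within the scatter, is expected: a number 2 percentage points lower from compound 2 to compound 3 (within the scatter). Compound 3 is therefore estimated to give 90%, with a range from 75% to 105%.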

Compound 3, largest response reached (Emax), in percent of the reference or control that the assay uses: 120%
The estimate for compound 3 lay 30 percentage points below the measured number; the measured number lies above the stated range.
By their numbers in this assay, from the lowest: compounds 1 and 2 (each within the scatter of the next); then compound 3.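

In this assay, this position can clearly change the maximal response: the step is a number 28 percentage points higher from compound 2 to compound 3 (beyond the scatter), as (pyridin-3-yl)methyl replaces phenyl on the oxygen and brings a ring with one hetero atom and one hydrogen-bond acceptor, where phenyl has neither. The new tail also stands apart from dimethylamino, with a number 35 percentage points higher from compound 1 to compound 3 (beyond the scatter), whereas the phenoxy and dimethylamino compounds could not be told apart, so the earlier pair gave no sign that a change here could matter this much. No supporting data bear on why the response rose.

This single change both adds a methylene link and puts a nitrogen into the ring, so the compounds shown cannot say which of the two goes with the higher response. A benzyloxy group would keep the link without the ring nitrogen, and (pyridin-2-yl)methoxy or (pyridin-4-yl)methoxy would test whether the place of that nitrogen matters.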